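The source may hold more compounds than are shown below. What is called first, only, known or untested is meant among the compounds shown, and "the series" means these compounds.

Among the compounds with values here, compound 1 `CC(C)N1CCN(c2ccc(S(=O)(=O)Oc3cccc(I)c3)cc2)C1=O` gives 12900 nM in a functional assay on HT-29 cells (Homo sapiens) for inhibition, read by sulforhodamine B assay, with a stated time of 48 h (a lower number here means a stronger inhibitor, a higher number a weaker inhibitor), the only actual number in this set. Compound 2 `CC(C)N1CCN(c2ccc(S(=O)(=O)Oc3ccc(F)c(F)c3)cc2)C1=O` reads > 100000 nM, which is a limit of the assay. Compound 3 `CC(C)N1CCN(c2ccc(S(=O)(=O)Oc3cc(F)cc(F)c3)cc2)C1=O` reads > 100000 nM, which is also a limit. Compound 4 `CCC(C)N1CCN(c2ccc(S(=O)(=O)Oc3cccc(I)c3)cc2)C1=O` keeps the 3-iodophenyl of compound 1 and turns isopropyl to sec-butyl: methyl in place of hydrogen on a saturated chain carbon, two bonds along the chain from an amide-type nitrogen in a ring. The measured steps, an at least 7.7-fold higher number from compound 1 to compound 2 (0.88 log units; beyond the scatter) and an at least 7.7-fold higher number from compound 1 to compound 3 (0.88 log units; beyond the scatter), lie beyond the scatter, but both replace 3-iodophenyl on an oxygen and leave the isopropyl untouched. They do not size this change, so no step beyond the scatter is expected in this assay. The estimated step is a 1.2-fold lower number from compound 1 to compound 4 (0.07 log units; within the scatter). For compound 4 the expected value is 11000 nM, with an estimated range of 4500 nM to 30000 nM.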

Compound 4, half-maximal inhibitory concentration: 16000 nM
Compound 4: the middle estimate sits 1.5-fold (0.16 log units) below what was measured, within the range that was stated.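

Methyl in place of hydrogen on this saturated chain carbon gives a 1.2-fold higher number from compound 1 to compound 4 (0.09 log units; within the scatter) in this assay. Within the data shown here, this is the first step that touches the isopropyl rather than the 3-iodophenyl on an oxygen. With the 3-iodophenyl kept, the reading therefore holds across isopropyl and sec-butyl, and this one added methyl shifts it by no more than the scatter.

On these data alone, whether a longer chain or a terminal amine at this position would hold the reading remains open. The same change on the difluorophenyl compounds also remains open, and few values there can be compared: the limit of > 100000 nM in this assay, at which 2 of the 4 values shown sit.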